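Swapping the group on the ring nitrogen of compound 2

The source may hold more compounds than are shown below. What is called first, only, known or untested is meant among the compounds shown, and "the series" means these compounds.

Compound 2 `O=C(O)c1cccc(S(=O)(=O)N2CCC(NS(=O)(=O)c3cc(S(=O)(=O)c4ccccc4)ccc3C(F)(F)F)CC2)c1` gives > 0.5 h in an in vitro ADME assay on microsomes from liver (Homo sapiens) for metabolic stability, tested at 1 uM (on this read-out lower numbers stand for a shorter-lived compound and higher numbers for a longer-lived compound), and this is a limit of the assay, not a number. Compound 2 thus sits at the limit of > 0.5 h in this assay, at which 2 of the 3 values shown sit. Compound 1 `O=C(c1ccc(Cl)nc1)N1CCC(NS(=O)(=O)c2cc(S(=O)(=O)c3ccccc3)ccc2C(F)(F)F)CC1` gives > 0.5 h, likewise a limit. Compound 3 `CC(C)(O)CCN1CCC(NS(=O)(=O)c2cc(S(=O)(=O)c3ccccc3)ccc2C(F)(F)F)CC1` gives < 0.0167 h, a limit at the other end.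

Compound 4 `O=C(C1CCNCC1)N1CCC(NS(=O)(=O)c2cc(S(=O)(=O)c3ccccc3)ccc2C(F)(F)F)CC1` has not yet been measured. It carries (piperidin-4-yl)carbonyl in place of (3-carboxyphenyl)sulfonyl on an amine nitrogen in a ring.

Three measured steps change this same place. The data show a step that the two limits leave unreadable from compound 1 to compound 2, which gives no size to build on. They also show an at least 29-fold lower number from compound 2 to compound 3 (1.47 log units; beyond the scatter), a large step. Compound 4 keeps a carbonyl on that nitrogen, as compound 1 does, so a fall as large as an at least 29-fold lower number from compound 1 to compound 3 (1.47 log units; beyond the scatter) is not expected. The estimated move is an at least 1.2-fold lower number from compound 2 to compound 4 (0.09 log units; that floor lies within the scatter), modest and downward if it can be read at all. Compound 4 is estimated at 0.4 h, with an expected range of 0.1 h to 1.5 h.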

Compound 4, half-life: > 0.5 h
Compound 4 gave a limit, no number; the forecaster's own chance of this, stated with the estimate: 50%; at least 1.2-fold (0.09 log units) between middle value and limit.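

The result adds a third group on this ring nitrogen that stands well clear of compound 3 in this assay, with an at least 29-fold higher number from compound 3 to compound 4 (1.47 log units; beyond the scatter). The (piperidin-4-yl)carbonyl group has one six-membered non-aromatic ring and no aromatic ring, unlike the groups of compounds 1 and 2, so an aromatic ring in this group is not needed to reach the upper end of the read-out. The value of compound 4 is a limit, and the steps linking it to compounds 1 and 2 cannot be read, so no order among the three can be given: the limit of > 0.5 h in this assay, at which 3 of the 4 values shown sit.

Going by these compounds, how far apart these three compounds truly lie remains open. So does the part played by the carbonyl, which a piperidin-4-yl group bonded directly to the ring nitrogen, or a small acetyl group there, would help to separate from the ring it carries.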